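Closing in on the acyl side chain of compound 3

The compounds below may be only part of what the source reports. "The series", "measured", "known", "first", "only" and "open" are said of these compounds alone.

Measured compounds:
compound 1 `O=C(CCCc1ccccc1)Nc1nc2cc(Cl)ccc2c(=O)s1` gives 76.4 nM
compound 2 `O=C(CCCc1ccccc1)Nc1nc2ccccc2c(=O)s1` gives 34.9 nM
compound 3 `COc1cccc(CCC(=O)Nc2nc3ccccc3c(=O)s2)c1` gives 95.3 nM

All three values come from an in vitro assay on cells for inhibition of Amine oxidase [flavin-containing] B (Homo sapiens), read by fluorescence and Amplex Red, with stated times of 30 min and 45 min; on this read-out higher numbers stand for weaker inhibition and lower numbers for stronger inhibition. Compound 3 stands at the highest number of the three, which here means the weakest inhibition: compound 1 sits close to it, within the usual scatter, while compound 2 lies clearly lower, beyond the scatter.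

Compound 4 `O=C(CCc1ccc(Cl)c(Cl)c1)Nc1nc2ccccc2c(=O)s1` is the next step from compound 3, and it differs only in the group on the side chain: 3,4-dichlorophenyl in place of 3-methoxyphenyl on a saturated chain carbon, two bonds along the chain from a carbonyl carbon.

Two measured steps exist. The step of a 2.2-fold lower number from compound 1 to compound 2 (0.34 log units; beyond the scatter) concerns a change on the shared core, not on the side chain, so it says little here. The step of a 2.7-fold higher number from compound 2 to compound 3 (0.44 log units; beyond the scatter) does concern the same place, and it shows that swapping the group there can move the number modestly, though it compares a different pair of groups. Among the measured compounds shown here, no measured compound carries a dichlorophenyl anywhere, so the direction for compound 4 cannot be read from the data. A modest movement in this assay is therefore expected, most likely back toward the lower numbers, with wide uncertainty. For compound 4 the estimated value is 60 nM, with a range from 20 nM to 180 nM, which would mean a step of a 1.6-fold lower number from compound 3 to compound 4 (0.20 log units; within the scatter).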

Compound 4, half-maximal inhibitory concentration: > 10000 nM
Compound 4 was reported as a limit; the forecaster's own chance of this, stated with the estimate: 3%; middle value at least 160-fold (2.22 log units) from the limit.
By their numbers in this assay, from the lowest: compound 2; then compounds 1 and 3 (each within the scatter of the next). At a limit, above all of these: compound 4.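

In this assay compound 4 is reported only as a limit: the limit of > 10000 nM in this assay, at which 1 of the 4 values shown sits.

The earlier compounds shown here showed only modest movement at this place on the side chain, whereas this single change gives an at least 100-fold higher number from compound 3 to compound 4 (2.02 log units; beyond the scatter), and measured against the benzyl group it gives an at least 280-fold higher number from compound 2 to compound 4 (2.45 log units; beyond the scatter). So this position does not merely fine-tune the number: one swap here can take inhibition out of the range the assay reports. The groups that leave and enter hold the same count of heavy atoms and the same kind of aromatic ring, so that count does not separate them; they differ in two chlorines against one methoxy oxygen, and the data give no cause for the loss.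

The compounds shown leave open whether one chlorine is enough, since neither 3-chlorophenyl nor 4-chlorophenyl stands among them, and whether the loss needs both together. They also leave open how an unsubstituted phenyl on this same chain would sit relative to compound 3, and whether 3,4-dichlorophenyl on the longer chain of compound 2 would behave the same way.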